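Hydroxymethyl added on the aryl ring of compound 1

The compounds below may be only part of what the source reports. "The series", "measured", "known", "first", "only" and "open" are said of these compounds alone.

Compound 1 `CN(C)c1ccc(-c2nc3c(s2)C(O)CNC3)cc1` gives 121000 nM in a functional assay on HCT-116 cells (Homo sapiens) for cytotoxicity, read by sulforhodamine B assay, with a stated time of 2 days (on this read-out higher numbers stand for weaker inhibition and lower numbers for stronger inhibition), the highest of the three numbers in hand. Compound 3 `OC1CNCc2nc(-c3ccc(N4CCCC4)cc3)sc21` gives 25000 nM and compound 2 `OCc1cc(N2CCCC2)ccc1-c1nc2c(s1)C(O)CCC2` gives 21000 nM; the values of compound 2 and compound 3 lie within the usual scatter of each other. Within the data shown here, the only single-place step measured so far is a 4.8-fold lower number from compound 1 to compound 3 (0.68 log units; beyond the scatter). Compound 4 `CN(C)c1ccc(-c2nc3c(s2)C(O)CNC3)c(CO)c1` differs from compound 1 by hydroxymethyl in place of hydrogen on an aromatic carbon. Among the measured compounds shown here, no measured step isolates this change: compound 2 carries a hydroxymethyl, but it also differs from compound 3 in the shared core, so its value cannot be read as the effect of the hydroxymethyl alone. The step from compound 1 to compound 3 concerns a different group and does not bear directly on the change to compound 4. For the measured compounds named here, with no comparable step to lean on, the expectation for compound 4 is no step beyond the scatter, a 1.2-fold lower number from compound 1 to compound 4 (0.08 log units; within the scatter). Compound 4 is therefore estimated at 100000 nM, within 35000 nM to 300000 nM.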

Compound 4, half-maximal inhibitory concentration: > 100000 nM
Compound 4 gave a limit, no number (the forecaster's own chance of this, stated with the estimate: 10%); the middle value lies on the limit itself.
By their numbers in this assay, from the lowest: compounds 2 and 3 (each within the scatter of the next); then compound 1.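

Among these compounds, compound 4 stands in this assay as a limit and not a number, so no step from compound 1 to compound 4 can be read: the limit of > 100000 nM in this assay, at which 1 of the 4 values shown sits. The compounds shown leave open what hydroxymethyl in place of hydrogen on an aromatic carbon does to the number of compound 1.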